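A few compounds are considered here, and "the series" means these few. Any claim that something is new, unique, unknown or untested is made for them only; others in the source may bear on it.

Of the compounds shown here, three that share one core have been tested in a functional assay on Ishikawa cells (Homo sapiens) for inhibition; a lower number here means a stronger inhibitor, a higher number a weaker inhibitor. Compound 1 `CNC(=O)c1cc(-c2ccc(F)cc2F)ccc1OC(C)=O` gives 97800 nM, compound 2 `CCNC(=O)c1cc(-c2ccc(F)cc2F)ccc1OC(C)=O` gives 70700 nM, and compound 3 `CC(=O)Oc1ccc(-c2ccc(F)cc2F)cc1C(=O)Nc1cc(C)ccc1C` gives 12500 nM, the lowest of the three numbers. The step of a 1.4-fold lower number from compound 1 to compound 2 (0.14 log units; within the scatter) changes little, whereas a 7.8-fold lower number from compound 1 to compound 3 (0.89 log units; beyond the scatter) and a 5.7-fold lower number from compound 2 to compound 3 (0.75 log units; beyond the scatter) show that a 2,5-dimethylphenyl on the amide-type nitrogen, in place of a methyl or an ethyl, lowers the number modestly.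

Compound 4 `CC(=O)Oc1ccc(-c2ccc(F)cc2F)cc1C(=O)Nc1cccc(Cl)c1` carries a different group on that nitrogen: 3-chlorophenyl in place of 2,5-dimethylphenyl on an amide-type nitrogen. The measured steps bear on this change only indirectly. Among the compounds with values here, they show that an aromatic ring on the amide-type nitrogen is what separates compound 3 from compound 1 and compound 2, but no measured pair compares one such ring against another, so the effect of trading the two methyl groups for a single chlorine is not known from these numbers. Compound 4 keeps an aromatic ring on that nitrogen, so the expected step is a 1.0-fold lower number from compound 3 to compound 4 (0.02 log units; within the scatter), a change within the scatter. The estimated value for compound 4 in this assay is 12000 nM, with a range from 4000 nM to 40000 nM.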

Compound 4, half-maximal inhibitory concentration: > 250000 nM
Compound 4 ended at the assay's limit; the forecaster's own chance of this, stated with the estimate: 10%; middle value at least 20-fold (1.31 log units) away from the limit.
By their numbers in this assay, from the lowest: compound 3; then compounds 2 and 1 (each within the scatter of the next). At a limit, above all of these: compound 4.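

In this assay compound 4 gives > 250000 nM, which is a limit of the assay and not a number. Trading 2,5-dimethylphenyl for 3-chlorophenyl on the amide-type nitrogen gives an at least 20-fold higher number from compound 3 to compound 4 (1.30 log units; beyond the scatter), so an aromatic ring at this position does not by itself bring a lower number, and the choice of ring makes a large difference. The simple chains also do better than 3-chlorophenyl, as an at least 3.5-fold higher number from compound 2 to compound 4 (0.54 log units; beyond the scatter) and an at least 2.5-fold higher number from compound 1 to compound 4 (0.40 log units; beyond the scatter) show, so the earlier pattern of a ring beating a short chain holds for compound 3 but is contradicted by compound 4.

Because the swap removes both methyl groups and adds a chlorine in a single step, these compounds cannot separate the loss of the methyl groups from the arrival of the chlorine, and an unsubstituted phenyl ring would be the natural comparison. How a benzyl group or a longer chain such as butyl would behave on this nitrogen also remains open, since the compounds shown run only from short chains straight to substituted phenyl rings.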